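Amino Group Added to the Fused Core of Compound 2

A few compounds are considered here, and "the series" means these few. Any claim that something is new, unique, unknown or untested is made for them only; others in the source may bear on it.

Compound 1, `Cc1nnc(NC(N)=O)cc1Cc1ccccc1`: 111 mg/kg
Compound 2, `Cc1nn2cnnc2cc1Cc1ccccc1`: 63 mg/kg
Compound 3, `Cc1nn2cnnc2cc1Cc1c(Cl)cccc1Cl`: 125 mg/kg

All three compounds have been tested in a functional assay on the whole organism with Mus musculus as the target; a lower number here means that less compound is needed, a higher number that more compound is needed for the effect. Compound 2 has the lowest number of the three in this assay, but the gap to compound 1 and the gap to compound 3 both fall within the usual scatter of repeated measurements, so the three cannot be ranked against one another on these numbers alone. None of the three differs from another in only one place, so no single structural change has yet been tied to a shift in this assay.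

Compound 4, `Cc1nn2c(N)nnc2cc1Cc1ccccc1`, is the next compound to be measured. It differs from compound 2 in one place: amino in place of hydrogen on an aromatic carbon. Going by the values given here, with no measured pair showing what such a change does here, the expectation rests on the spread of the three numbers already seen, which is narrow. A step from compound 2 to compound 4 of about a 1.0-fold higher number from compound 2 to compound 4 (0.01 log units; within the scatter) is expected, which is within the scatter and so in no clear direction. Compound 4 is expected to give about 65 mg/kg in this assay, with a likely range from 25 mg/kg to 170 mg/kg.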

Compound 4, dose for half-maximal effect: 94 mg/kg
Beside the measured number, compound 4's estimate is 1.4-fold (0.16 log units) below it; low and high end bracket the measured number.
By their numbers in this assay, from the lowest: compounds 2, 4, 1 and 3 (each within the scatter of the next).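

In this assay, amino in place of hydrogen on this aromatic carbon, which lies between two ring nitrogen atoms, gives a 1.5-fold higher number from compound 2 to compound 4 (0.17 log units; within the scatter). Going by these compounds alone, this is the first single change that can be read, and it shows that a hydrogen at this position can give way to an amino group with no shift that stands out from the differences seen between repeated measurements, at least in this one pair. No measurement available here bears on what lies behind this result.

Going by these compounds, a single small group at one position says little about the position as a whole, so it remains open whether a methyl group, a chlorine atom or a longer chain such as a dimethylamino or acetylamino group on the same carbon would also stay within the scatter or would instead produce a clear step. On these data alone, it is also open whether the same amino group would give a similar result when added to compound 3, which carries two chlorine atoms on its outer ring.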